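Amide aryl changes: compound 3 to compound 4

This account rests on a few compounds, and the source may have more. Where it says the series, first, only, none or still open, it means among the compounds named here.

Clearance in an in vitro ADME assay on microsomes from liver (Mus musculus) for pharmacokinetics, read by LC-MS, with a stated time of 10 min, tested at 1 uM (on this read-out lower numbers stand for slow clearance and higher numbers for fast clearance), so far:
- compound 1 `CN1C[C@H](C(=O)Nc2ccc(F)cc2)[C@@H](c2ccc(/C=C/C(=O)Nc3ccccc3N)cc2)C1` gives 34 mL/min/kg here
- compound 2 `CN1C[C@H](C(=O)Nc2ccc(C3CC3)cc2)[C@@H](c2ccc(/C=C/C(=O)Nc3ccccc3N)cc2)C1` gives 60 mL/min/kg here
- compound 3 `CN1C[C@H](C(=O)Nc2cccc(Cl)c2)[C@@H](c2ccc(/C=C/C(=O)Nc3ccccc3N)cc2)C1` gives 58 mL/min/kg here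

Compound 3 at 58 mL/min/kg lies within the scatter of both other measured compounds, so no order among the three can be read. The change to compound 4 `CN1C[C@H](C(=O)Nc2ccc(F)c(F)c2)[C@@H](c2ccc(/C=C/C(=O)Nc3ccccc3N)cc2)C1` is 3,4-difluorophenyl in place of 3-chlorophenyl on an amide-type nitrogen, counted as 3,4-difluorophenyl in place of 3-chlorophenyl on an amide-type nitrogen in full. Going by the values given here, three measured steps bear on it, all in this aryl group: a 1.7-fold higher number from compound 1 to compound 3 (0.23 log units; within the scatter) and a 1.0-fold lower number from compound 2 to compound 3 (0.01 log units; within the scatter) and a 1.8-fold higher number from compound 1 to compound 2 (0.25 log units; within the scatter) are each within the scatter. No measured change in this group has yet gone beyond the scatter, so in this assay no clear step is expected. Compound 1 at 34 mL/min/kg carries 4-fluorophenyl, which points weakly towards a somewhat lower number. The expected step is a 1.3-fold lower number from compound 3 to compound 4 (0.13 log units; within the scatter) and it is estimated to stay within the scatter. For compound 4 the estimate is 43 mL/min/kg with an expected range from 26 mL/min/kg to 70 mL/min/kg on this read-out.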

Compound 4, clearance: 46 mL/min/kg
For compound 4 the middle estimate is 1.1-fold (0.03 log units) below the measured one; the measured number falls inside the stated range.
By their numbers in this assay, from the lowest: compounds 1, 4, 3 and 2 (each within the scatter of the next).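

In this assay the exchange of 3-chlorophenyl for 3,4-difluorophenyl on the amide-type nitrogen gives a 1.3-fold lower number from compound 3 to compound 4 (0.10 log units; within the scatter) and the exchange of 4-cyclopropylphenyl for the same group gives a 1.3-fold lower number from compound 2 to compound 4 (0.12 log units; within the scatter) while both stay within the scatter. The addition of fluoro in place of hydrogen on an aromatic carbon, the smallest change in the set, gives a 1.4-fold higher number from compound 1 to compound 4 (0.13 log units; within the scatter) and also stays within the scatter, so all six steps among the four compounds now lie inside it and no group tried at this position stands apart. Nothing measured here offers an explanation for these numbers.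

The groups shown on the amide-type nitrogen are all substituted phenyl rings, and whether any group there can move the number beyond the scatter stays open. A carboxylic acid or a morpholine on that phenyl, or an alkyl chain in its place, would test this.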